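Swapping an Aromatic Side Group in a Dog Clearance Series

This account rests on a few compounds, and the source may have more. Where it says the series, first, only, none or still open, it means among the compounds named here.

Measured compounds:
- compound 1 `CC(C)c1ncc([C@@H](CCCCCCc2ccc3c(n2)NCCC3)CC(=O)O)cn1`: "not determined" (no result reported)
- compound 2 `O=C(O)CC(NC(=O)CCCCc1ccc2c(n1)NCCC2)c1cncnc1`: 26 mL/min/kg

Compound 1 carries a long saturated chain ending in a carboxylic acid, with a 2-isopropylpyrimidin-5-yl group on the chain. In an in vivo ADME assay on the whole organism (Canis lupus familiaris) for pharmacokinetics (a lower number here means slower removal, a higher number faster removal of the compound), compound 1 gives "not determined" (no result reported), so it gives no anchor of its own. Within the data shown here, compound 2 shares the core but holds an amide in its chain and a plain pyrimidine; in this assay compound 2 gives 26 mL/min/kg, the only measurement available here.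

Compound 3 `O=C(O)C[C@H](CCCCCCc1ccc2c(n1)NCCC2)c1ccc2c(c1)OCC2` is reached from compound 1 by one change: a group of 9 heavy atoms (8 carbon, 1 oxygen; one five-membered non-aromatic ring with 1 hetero atom, one six-membered aromatic ring of carbon only) in place of a group of 9 heavy atoms (7 carbon, 2 nitrogen; one six-membered aromatic ring with 2 hetero atoms), on a saturated chain carbon bound to two saturated chain carbons

Among the measured compounds shown here, with no measured step to compare against, the size and direction of the change in this assay from compound 1 to compound 3 cannot be read from these data; the change could fall anywhere within or beyond the usual scatter. Taking the only measured value as a rough guide, compound 3 is expected to give about 15 mL/min/kg in this assay, estimated within a range from 5 mL/min/kg to 40 mL/min/kg.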

Compound 3, clearance: 7.9 mL/min/kg
The estimate for compound 3 lay 1.9-fold (0.28 log units) above the measured number, and the stated range covers the measured number.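

In this assay, among these compounds, compound 3 gives 7.9 mL/min/kg and compound 1 has "not determined" (no result reported) as its entry, so no step between compound 1 and compound 3 can be read. The compounds shown leave open how far replacing the 2-isopropylpyrimidin-5-yl group shifts the clearance. Nothing shown offers an explanation for the result.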